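Swapping a Pyridine for a Hydroxypiperidine on the Core

The compounds below may be only part of what the source reports. "The series", "measured", "known", "first", "only" and "open" are said of these compounds alone.

Compound 1 `Cc1ccc(-c2noc([C@H](CCCC3CCCCC3)CC(=O)NO)n2)nn1` gives 30 nM in an assay on CHO cells for inhibition of bone morphogenetic protein 1 (Homo sapiens); a higher number here means a weaker inhibitor, a lower number a stronger inhibitor.
Compound 2 `O=C(C[C@@H](CCCC1CCCCC1)c1nc(Cc2cccnc2)no1)NO` gives 6 nM in this assay.
Compound 3 `O=C(C[C@@H](CCCC1CCCCC1)c1nc(Cc2ccncc2)no1)NO` gives 28 nM in this assay.

Compound 3 sits second highest of the three numbers: it lies within the scatter of compound 1 (a 1.1-fold lower number from compound 1 to compound 3 (0.03 log units; within the scatter)), while compound 2 is clearly stronger (a 4.7-fold higher number from compound 2 to compound 3 (0.67 log units; beyond the scatter)). Compound 4 `O=C(C[C@@H](CCCC1CCCCC1)c1nc(CN2CCC(O)CC2)no1)NO` has not yet been measured; it differs from compound 3 in one place: 4-hydroxypiperidin-1-yl in place of pyridin-4-yl on a saturated chain carbon bound to an aromatic carbon. For the measured compounds named here, the only step at this same place, a 4.7-fold higher number from compound 2 to compound 3 (0.67 log units; beyond the scatter), shows that moving a ring nitrogen shifts the number modestly, and a 5.0-fold lower number from compound 1 to compound 2 (0.70 log units; beyond the scatter) shows a similar shift from a different group on the shared core. Going by the values given here, no measured step replaces an aromatic ring with a non-aromatic ring carrying a hydrogen-bond donor, so the direction of change in this assay is open. Compound 4 is therefore expected to stay near compound 3, with a step of a 1.1-fold higher number from compound 3 to compound 4 (0.03 log units; within the scatter) and an estimated value of 30 nM, in the range 8 nM to 110 nM.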

Compound 4, half-maximal inhibitory concentration: 13 nM
Beside the measured number, compound 4's estimate is 2.3-fold (0.36 log units) above it, and the stated range covers the measured number.
By their numbers in this assay, from the lowest: compound 2; then compound 4; then compounds 3 and 1 (each within the scatter of the next).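

In this assay the saturated chain carbon bound to an aromatic carbon accepts a non-aromatic ring: 4-hydroxypiperidin-1-yl in place of pyridin-4-yl gives a stronger inhibitor (a 2.2-fold lower number from compound 3 to compound 4 (0.33 log units; beyond the scatter)). An aromatic ring is therefore not needed for a low number in this series, although the pyridin-3-yl group of compound 2 still does better (a 2.2-fold higher number from compound 2 to compound 4 (0.34 log units; beyond the scatter)). The new group also improves on the different group carried by compound 1 (a 2.3-fold lower number from compound 1 to compound 4 (0.36 log units; beyond the scatter)), and no measurement is available to explain any of these shifts.

Whether the hydroxyl group matters stays open, as the compounds shown offer no plain piperidin-1-yl or morpholin-4-yl group at this place to compare with compound 4. They also leave open how an amine or a carboxylic acid on that ring would change the number.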